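The source may hold more compounds than are shown below. What is called first, only, known or untested is meant among the compounds shown, and "the series" means these compounds.

Of the compounds shown here, two built on one shared core have been tested in an ADME assay on HEL cells (Homo sapiens) for cytotoxicity, with a stated time of 3 days; on this read-out higher numbers stand for lower toxicity in this test and lower numbers for higher toxicity in this test. Compound 1, `CCC1(Cc2ccccc2)OS(=O)(=O)C=C1OCC(=O)OC`, and compound 2, `CCC1(Cc2ccccc2)OS(=O)(=O)C=C1OCc1cccc(Cl)c1`, differ in a single group on a saturated chain carbon bound to an oxygen on an unsaturated carbon. For compound 1 the test reports only > 200000 nM, which is a limit of the assay rather than a measured number. Compound 1 thus sits at the limit of > 200000 nM in this assay, at which 1 of the 2 values shown sits. Going by the values given here, compound 2 gives 50000 nM, the only measured number in this set. The step of an at least 4.0-fold lower number from compound 1 to compound 2 (0.60 log units; beyond the scatter) therefore shows compound 2 as the more toxic of the pair.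

Compound 3, `C=CCOC1=CS(=O)(=O)OC1(CC)Cc1ccccc1`, has not yet been measured; it carries vinyl in place of 3-chlorophenyl on a saturated chain carbon bound to an oxygen on an unsaturated carbon. Among the compounds with values here, the one measured step ran toward higher toxicity when an aromatic ring entered at this position, so taking that ring away again, down to a small vinyl, is expected to move the number back in the other direction, possibly as far as the limit. The expected step of a 3.0-fold higher number from compound 2 to compound 3 (0.48 log units; beyond the scatter) puts compound 3 at an estimated 150000 nM, within a range from 60000 nM to 400000 nM.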

Compound 3, half-maximal cytotoxic concentration: > 200000 nM
Compound 3: a limit, no number; the forecaster's own chance of this, stated with the estimate: 40%; at least 1.3-fold (0.12 log units) between middle value and limit.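

In this assay, putting vinyl in place of 3-chlorophenyl on a saturated chain carbon bound to an oxygen on an unsaturated carbon gives an at least 4.0-fold higher number from compound 2 to compound 3 (0.60 log units; beyond the scatter), so a second group, quite unlike methoxycarbonyl, also leaves the higher toxicity of compound 2 behind. Compound 1 and compound 3 both stand at a limit of the test and not at a number: the limit of > 200000 nM in this assay, at which 2 of the 3 values shown sit. The step between these two cannot be read, so they cannot be ranked against each other, but among the three compounds shown only the one carrying 3-chlorophenyl gives a measured number, and none of the three goes against this link between that group and higher toxicity.

On these data alone, whether the ring itself or its chlorine goes with the lower number stays open, since a plain benzyl group without the chlorine would be needed to separate the two. As far as these compounds go, how a saturated propyl chain or a group carrying an amine would behave at this place also remains open.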